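The compounds below may be only part of what the source reports. "The series", "measured", "known", "first", "only" and "open" are said of these compounds alone.

Measured compounds:
compound 1 `CC(C)CNc1nc(N2CCN(Cc3ccccc3)CC2)ncc1C(=O)NCc1ccccc1`: 79 nM
compound 2 `CC(C)CNc1nc(N2CCN(Cc3ccccc3)CC2)ncc1C(=O)NCc1ccccn1`: "not active" (no number reported)
compound 3 `O=C(NCc1ccccc1)c1cnc(N2CCN(C(=O)c3ccccc3)CC2)nc1NC1CC1`: "not active" (no number reported)

In a functional assay on HEK293 cells for agonist activity at transient receptor potential cation channel subfamily A member 1 (Homo sapiens), read by fluorescence and calcium flux, with stated times of 1 s and 60 s (a lower number here means that less compound is needed, a higher number that more compound is needed for the effect), compound 1 gives 79 nM and is the only one of the three with a number. Compound 2 is reported in this assay as "not active" (no number reported), without a number. Compound 3 likewise gives "not active" (no number reported) in this assay, so it stands without a single number, and a second entry of the series also has none. Going by the values given here, no step between measured compounds is given, so where compound 3 stands relative to compound 1 cannot be put in a size.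

Compound 4 `O=C(NCc1ccccc1)c1cnc(N2CCN(CC3CCCOC3)CC2)nc1NC1CC1` differs from compound 3 in one place: (oxan-3-yl)methyl in place of benzoyl on an amine nitrogen in a ring. The new group is joined to the ring nitrogen through a single carbon, as the benzyl group of compound 1 is. Among the compounds with values here, compound 3 gave no number, so no step from it can be sized in this assay; the reader is left with the values of compound 1 and compound 3 as they stand. Compound 4 is expected to return a number in this assay, estimated at 500 nM, with a range from 100 nM to 5000 nM.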

Compound 4, half-maximal effective concentration: 109 nM
Estimate against measurement, compound 4: 4.6-fold (0.66 log units) above; the measured number falls inside the stated range.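

Going by these compounds alone, compound 3 stands as "not active" (no number reported) while compound 4 gives 109 nM and so no step between compound 3 and compound 4 can be read. No measured evidence bears on this result. The compounds shown leave open how large the effect of exchanging benzoyl for (oxan-3-yl)methyl is.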